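The compounds below may be only part of what the source reports. "The series", "measured", "known", "first", "only" and "open" are said of these compounds alone.

Measured so far in a functional assay on CNE-2 cells (Homo sapiens) for cytotoxicity, read by MTT assay, with a stated time of 72 h; a higher number here means a weaker inhibitor, a lower number a stronger inhibitor:
- compound 1 `COc1cc2ncnc(NNC(=S)NC(=O)c3ccccc3)c2cc1OC`: 8180 nM
- compound 2 `COc1cc2ncnc(NNC(=S)NC(=O)c3ccccc3Cl)c2cc1OC`: 9670 nM
- compound 3 `COc1cc2ncnc(NNC(=S)NC(=O)c3ccc(C)cc3)c2cc1OC`: 33300 nM

Compound 3 stands with the highest number of the three, and both its steps are beyond the scatter: a 4.1-fold higher number from compound 1 to compound 3 (0.61 log units; beyond the scatter) and a 3.4-fold higher number from compound 2 to compound 3 (0.54 log units; beyond the scatter). Compounds 1 and 2 sit within the scatter of each other, a 1.2-fold higher number from compound 1 to compound 2 (0.07 log units; within the scatter).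

Compound 4 `COc1cc2ncnc(NNC(=S)NC(=O)c3ccccc3OC)c2cc1OC` is not yet measured. Against compound 3 the change is 2-methoxyphenyl in place of 4-methylphenyl on a carbonyl carbon.

Among the compounds with values here, two steps bear on this. The step of a 3.4-fold higher number from compound 2 to compound 3 (0.54 log units; beyond the scatter) shows that moving from a 2-chlorophenyl to the 4-methylphenyl of compound 3 gave a higher number, so the reverse direction, back to a group carrying a single substituent on the same position, should lower it. The step of a 1.2-fold higher number from compound 1 to compound 2 (0.07 log units; within the scatter) shows that a substituent on that position left the number essentially unchanged from the unsubstituted compound 1. A moderate fall in this assay is therefore expected for compound 4, roughly reversing a 3.4-fold higher number from compound 2 to compound 3 (0.54 log units; beyond the scatter). For compound 4 the estimate is 10000 nM, in the range 4000 nM to 25000 nM, a step of a 3.3-fold lower number from compound 3 to compound 4 (0.52 log units; beyond the scatter) that is expected.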

Compound 4, half-maximal inhibitory concentration: 8410 nM
Compound 4: the middle estimate sits 1.2-fold (0.08 log units) above what was measured, and the stated range covers the measured number.
By their numbers in this assay, from the lowest: compounds 1, 4 and 2 (each within the scatter of the next); then compound 3.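

In this assay, 2-methoxyphenyl in place of 4-methylphenyl on the carbonyl carbon gives a 4.0-fold lower number from compound 3 to compound 4 (0.60 log units; beyond the scatter) and brings the number back to the level of the other compounds. Methoxy in place of chloro gives a 1.1-fold lower number from compound 2 to compound 4 (0.06 log units; within the scatter) and methoxy in place of hydrogen gives a 1.0-fold higher number from compound 1 to compound 4 (0.01 log units; within the scatter), so the series now holds three compounds that these changes do not separate, and among the compounds shown only the 4-methylphenyl of compound 3 stands apart. Nothing available here accounts for that gap.

Going by these compounds, whether the higher number of compound 3 is tied to the methyl group itself stays open. Also open, on these data alone, is what an amine or a carboxylic acid on the phenyl ring would do, or a longer chain in place of methoxy.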